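A few compounds are considered here, and "the series" means these few. Any claim that something is new, unique, unknown or untested is made for them only; others in the source may bear on it.

Working notes on the series built on the shared core of compound 1 `O=S(=O)(NCCCNCc1ccc(Cl)cc1)c1cc(C(F)(F)F)cc(C(F)(F)F)c1`, compared in a toxicity assay on MCF-10A cells (Homo sapiens) for inhibition, read by MTT assay, with a stated time of 72 h; a lower number here means a stronger inhibitor of growth, a higher number a weaker inhibitor of growth. Compound 1 gives 2300 nM. Compound 2 `O=S(=O)(NCCCNCc1ccc(C(F)(F)F)cc1)c1cc(C(F)(F)F)cc(C(F)(F)F)c1` gives 3300 nM, the step being a 1.4-fold higher number from compound 1 to compound 2 (0.16 log units; within the scatter). Among the measured compounds shown here, compound 3 `O=S(=O)(NCCCNCC1COc2ccccc2O1)c1cc(C(F)(F)F)cc(C(F)(F)F)c1` gives 3200 nM; on the three numbers so far it stands second highest, nearest to compound 2 and furthest from compound 1, with neither gap beyond the scatter. The steps leading to compound 3 read a 1.4-fold higher number from compound 1 to compound 3 (0.14 log units; within the scatter) and a 1.0-fold lower number from compound 2 to compound 3 (0.01 log units; within the scatter).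

Compound 4 `O=S(=O)(NCCCNCc1ccc(Br)cc1)c1cc(C(F)(F)F)cc(C(F)(F)F)c1` differs from compound 3 in one place: 4-bromophenyl in place of 2,3-dihydro-1,4-benzodioxin-2-yl on a saturated chain carbon bound to an amine nitrogen. For the measured compounds named here, two measured steps bear on this change, since they run the same exchange in reverse: a 1.4-fold higher number from compound 1 to compound 3 (0.14 log units; within the scatter) and a 1.0-fold lower number from compound 2 to compound 3 (0.01 log units; within the scatter), neither beyond the scatter. The step of a 1.4-fold higher number from compound 1 to compound 2 (0.16 log units; within the scatter) shows that swapping the group on the benzyl ring between chloro and trifluoromethyl also stayed within the scatter, and bromo is a halogen in the same place as the chloro of compound 1. No step beyond the scatter is therefore expected from compound 3 to compound 4; if anything, a slightly lower number, following compound 1. Compound 4 is estimated at 2500 nM, expected to fall between 1200 nM and 5200 nM. The expected step is a 1.3-fold lower number from compound 3 to compound 4 (0.11 log units; within the scatter).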

Compound 4, concentration for 50% growth inhibition: 3100 nM
Compound 4: the middle estimate sits 1.2-fold (0.09 log units) below what was measured; the measured number falls inside the stated range.
By their numbers in this assay, from the lowest: compounds 1, 4, 3 and 2 (each within the scatter of the next).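

In this assay, the 4-bromophenyl group on a saturated chain carbon bound to an amine nitrogen reads the same as 2,3-dihydro-1,4-benzodioxin-2-yl, with a 1.0-fold lower number from compound 3 to compound 4 (0.01 log units; within the scatter), so this exchange now stays within the scatter for a third substituted phenyl partner. On the aromatic carbon, bromo adds a third group to the comparison, with a 1.1-fold lower number from compound 2 to compound 4 (0.03 log units; within the scatter) and a 1.3-fold higher number from compound 1 to compound 4 (0.13 log units; within the scatter), and chloro, bromo and trifluoromethyl are not told apart by these numbers. No supporting data bear on why these compounds lie so close together.

All the steps among these four compounds lie within the scatter, which leaves open whether any change at either place can move the number beyond it. Also open, on these data alone, is how a carboxylic acid or an amine on that aromatic carbon would read in place of bromo, and how a longer chain would read in place of the present one.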